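Permeability notes on a 4-aminoquinoline diamine series

The source may hold more compounds than are shown below. What is called first, only, known or untested is meant among the compounds shown, and "the series" means these compounds.

Measured compounds and values in an ADME assay for permeability, using PAMPA, with a stated time of 30 min, at pH 7.4; a higher number here means that the compound crosses the layer faster, a lower number that the compound crosses the layer more slowly:
- compound 1 `Fc1ccc(-c2ccc3c(NCCCNCc4ccco4)ccnc3c2)cc1`: 237 10^-6 cm/s
- compound 2 `COc1cccc(CNCCCNc2ccnc3cc(-c4ccc(C(F)(F)F)cc4)ccc23)c1O`: 237 10^-6 cm/s
- compound 3 `COc1cccc(CNCCCNc2ccnc3cc(-c4cc(C(F)(F)F)cc(C(F)(F)F)c4)ccc23)c1O`: 237 10^-6 cm/s

In this assay compound 2 stands level with compound 1 and compound 3 at the digits shown; the three readings are the same within the scatter, so no order among them can be stated. Whether a reading this high is a plateau of the method cannot be told from these numbers alone.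

Compound 4 `COc1cccc(CNCCCNc2ccnc3cc(Oc4ccccc4)ccc23)c1O` has not yet been measured. It differs from compound 2 by phenoxy in place of 4-(trifluoromethyl)phenyl on an aromatic carbon, the group that leaves being 4-(trifluoromethyl)phenyl and the group that enters being phenoxy, both on the same aromatic carbon of the shared core.

Among the compounds with values here, no step between measured compounds is available to set the size of this change. Given that compound 1, compound 2 and compound 3 all sit at one reading, the expectation is that the change from compound 2 to compound 4 gives a step of a 1.1-fold lower number from compound 2 to compound 4 (0.02 log units; within the scatter), none beyond the scatter. Compound 4 is estimated at 225 10^-6 cm/s, with a range of 120 10^-6 cm/s to 300 10^-6 cm/s.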

Compound 4, apparent permeability: 317 10^-6 cm/s
Estimate against measurement, compound 4: 1.4-fold (0.15 log units) below; measured number outside the range, above it.
By their numbers in this assay, from the lowest: compounds 1, 2, 3 and 4 (each within the scatter of the next).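

In this assay, within the data shown here, phenoxy in place of 4-(trifluoromethyl)phenyl on this aromatic carbon of the shared core gives a 1.3-fold higher number from compound 2 to compound 4 (0.13 log units; within the scatter) as the first readable step at this position, so the two groups cannot be told apart in this read-out. Among these compounds, compound 4, at 317 10^-6 cm/s in this assay, also shows that the reading shared by compounds 1, 2 and 3 is not the only value the method prints, although one reading within the scatter does not settle whether a plateau exists. No measurement offered with this result bears on a cause.

Going by these compounds, whether an amine or a carboxylic acid on this same aromatic carbon would give a step beyond the scatter stays open. A longer chain in place of the phenoxy group is equally untested among the compounds shown.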